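Halogen on the aryl ether ring of compound 1

The source may hold more compounds than are shown below. What is called first, only, known or untested is meant among the compounds shown, and "the series" means these compounds.

Compound 1 `CN(C)CC#Cc1ccc(OCCCc2sc(N3CCc4cccc(C(=O)Nc5nc6ccccc6s5)c4C3)nc2C(=O)O)cc1` is the parent of this pair. Going by the values given here, in a functional assay on NCI-H146 cells (Homo sapiens) for cytotoxicity, with a stated time of 48 h, in the presence of a further agent that is not named here (a higher number here means that more compound is needed for the effect, a lower number that less compound is needed), compound 1 gives 600 nM, the highest of the two numbers so far; the nearest neighbour, compound 2 `CN(C)CC#Cc1ccc(OCCCc2sc(N3CCc4cccc(C(=O)Nc5nc6ccccc6s5)c4C3)nc2C(=O)O)c(Cl)c1`, gives 180 nM. Among the compounds with values here, the one measured step, chloro in place of hydrogen on an aromatic carbon, is a 3.3-fold lower number from compound 1 to compound 2 (0.52 log units; beyond the scatter). Compound 3 `CN(C)CC#Cc1ccc(OCCCc2sc(N3CCc4cccc(C(=O)Nc5nc6ccccc6s5)c4C3)nc2C(=O)O)cc1F` differs from compound 1 by fluoro in place of hydrogen on an aromatic carbon. The step from compound 1 to compound 2 is the only one that bears on this, and only loosely: it adds a halogen to the same six-membered ring, but chloro rather than fluoro and, as the structures show, not at the same carbon. For compound 3 a small step in the lower direction, or none beyond the scatter, is therefore expected, a 1.3-fold lower number from compound 1 to compound 3 (0.12 log units; within the scatter). Compound 3 is estimated at 450 nM, with a range of 200 nM to 1000 nM.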

Compound 3, half-maximal effective concentration: 51 nM
Estimate against measurement, compound 3: 8.8-fold (0.95 log units) above; the whole stated range lies above it.
By their numbers in this assay, from the lowest: compound 3; then compound 2; then compound 1.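

In this assay fluoro on the aromatic carbon ortho to the 3-(dimethylamino)prop-1-yn-1-yl group and meta to a large group gives a 12-fold lower number from compound 1 to compound 3 (1.07 log units; beyond the scatter) and counts as a large step on a single added atom. The chloro change, on another carbon of the same ring, gave a 3.3-fold lower number from compound 1 to compound 2 (0.52 log units; beyond the scatter) and counts as modest, so a halogen on this ring does not give one fixed step. Both the halogen and the carbon differ between these two changes, and the pair cannot show which of the two matters.

Open, from the compounds shown here alone, is whether chloro or methoxy on the carbon that carries fluoro in compound 3, or fluoro on the carbon that carries chloro in compound 2, would give a step of this size. Nothing measured here accounts for the size of the fluoro step.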